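Chain Length and a Shared Amide Core

This account rests on a few compounds, and the source may have more. Where it says the series, first, only, none or still open, it means among the compounds named here.

Measured compounds:
Compound 1, `COc1cc(/C=C/C(=O)NCCCCC(N)CN)ccc1O`: 52.2%
Compound 2, `CC(C)(C)OC(=O)NCC(CCCCNC(=O)CCn1cccc(O)c1=O)NC(=O)OC(C)(C)C`: 90%
Compound 3, `NCC(N)CCCNC(=O)CCn1cccc(O)c1=O`: 76.4%

In a physicochemical assay, read by spectrophotometry, with a stated time of 10 min, tested at 1 mM, in the presence of a further agent that is not named here (a higher number here means a stronger effect of the compound at the concentration tested, a lower number a weaker effect), compound 3 stands second highest of the three numbers; its nearest neighbour is compound 2, whose number lies higher by a gap beyond the scatter, and the furthest is compound 1, whose number lies lower, again beyond the scatter. Compound 4, `NCC(N)CCCCNC(=O)CCn1cccc(O)c1=O`, shares the core of compound 3 and differs from it in one place: 2,3-diaminopropyl in place of 1,2-diaminoethyl on a saturated chain carbon, three bonds along the chain from an amide-type nitrogen. Among the compounds with values here, no pair of measured compounds shows a step of this kind, so nothing directly tells how this assay answers one added chain carbon. With the rest of the molecule unchanged, the step expected in this assay is a number 1.4 percentage points lower from compound 3 to compound 4 (within the scatter), that is, none beyond the scatter. Compound 4 is therefore estimated at 75%, within a range from 60% to 88%.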

Compound 4, a percentage reported as activity, at one concentration (the size of the read-out at that concentration, not a potency): 85.6%
For compound 4 the middle estimate is 10.6 percentage points below the measured one; the range from low to high includes it.
By their numbers in this assay, from the lowest: compound 1; then compounds 3, 4 and 2 (each within the scatter of the next, the first and the last beyond it).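

In this assay, within the data shown here, the first direct reading at this position is a number 9.2 percentage points higher from compound 3 to compound 4 (within the scatter) and so the two compounds cannot be told apart. On a saturated chain carbon, three bonds along the chain from an amide-type nitrogen, 2,3-diaminopropyl and 1,2-diaminoethyl thus read alike with the rest of the molecule unchanged. Nothing available explains this result. As far as these compounds go, whether the longer 3,4-diaminobutyl would also read alike remains open. So does the outcome of a carboxylic acid in place of the terminal amine at this position.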